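Aryl Substituent Series: Hydroxy-Methoxy Variant After Acetyl

A few compounds are considered here, and "the series" means these few. Any claim that something is new, unique, unknown or untested is made for them only; others in the source may bear on it.

Measured compounds in a functional assay on SGC-7901 cells (Homo sapiens) for antiproliferative activity, read by MTT assay, with a stated time of 72 h; on this read-out higher numbers stand for weaker inhibition and lower numbers for stronger inhibition:
- compound 1 `COc1cc(-n2cnc3ccc(-c4cccc(N)c4)cc32)cc(OC)c1OC` gives 21 nM
- compound 2 `COc1cc(-n2cnc3ccc(-c4cccc([N+](=O)[O-])c4)cc32)cc(OC)c1OC` gives 380 nM
- compound 3 `COc1cc(-n2cnc3ccc(-c4ccc(C(C)=O)cc4)cc32)cc(OC)c1OC` gives 450 nM

Compound 3 stands at the highest number of the three. Its nearest neighbour is compound 2, with a 1.2-fold higher number from compound 2 to compound 3 (0.07 log units; within the scatter), a gap within the scatter, so no order between compound 2 and compound 3 is claimed. Its furthest neighbour is compound 1, with a 21-fold higher number from compound 1 to compound 3 (1.33 log units; beyond the scatter), well beyond the scatter.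

Compound 4 `COc1ccc(-c2ccc3ncn(-c4cc(OC)c(OC)c(OC)c4)c3c2)cc1O` is the next member. Relative to compound 3 the change is 3-hydroxy-4-methoxyphenyl in place of 4-acetylphenyl on an aromatic carbon.

Within the data shown here, two measured steps bear on this. The step from compound 1 to compound 3 shows that exchanging the 3-aminophenyl, which carries one hydrogen-bond donor, for the 4-acetylphenyl, which carries none, raised the number greatly. The step from compound 2 to compound 3 shows that swapping one donor-free aryl for another left the number unchanged within the scatter. Among the measured compounds shown here, the group entering in compound 4 again carries one hydrogen-bond donor and two hydrogen-bond acceptors, so a move toward the number of compound 1 is expected, though the donor is a hydroxy rather than an amino and the methoxy is an added element with no precedent here; the expected step is therefore a 4.1-fold lower number from compound 3 to compound 4 (0.61 log units; beyond the scatter), downward, beyond the scatter but short of a full return to compound 1. For compound 4 the estimated value in this assay is 110 nM, with a range from 30 nM to 420 nM.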

Compound 4, half-maximal inhibitory concentration: 44 nM
Compound 4: middle estimate off by 2.5-fold (0.40 log units), on the high side; measured number inside the range.
By their numbers in this assay, from the lowest: compound 1; then compound 4; then compounds 2 and 3 (each within the scatter of the next).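

In this assay the low numbers at this position are no longer tied to the 3-aminophenyl group, since 3-hydroxy-4-methoxyphenyl gives a 10-fold lower number from compound 3 to compound 4 (1.01 log units; beyond the scatter) and an 8.6-fold lower number from compound 2 to compound 4 (0.94 log units; beyond the scatter) against the two aryl groups at the high end. A gap to the amino compound remains, with a 2.1-fold higher number from compound 1 to compound 4 (0.32 log units; beyond the scatter) as a modest step beyond the scatter. Across these four compounds, the aryl groups bearing amino or hydroxy sit at the low end and those bearing nitro or acetyl at the high end, with no compound going against this.

Hydroxy and methoxy enter together, so their separate shares cannot be read, and 3-hydroxyphenyl, 4-methoxyphenyl or a 3-carboxyphenyl group would test this. No supporting data are available to explain why the numbers move.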